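Replacing oxolan-3-yl with methyl in the series

This account rests on a few compounds, and the source may have more. Where it says the series, first, only, none or still open, it means among the compounds named here.

Measured in a functional assay on A549 cells (Homo sapiens) for cytotoxicity, read by MTT assay, with a stated time of 72 h; on this read-out higher numbers stand for weaker inhibition and lower numbers for stronger inhibition
- compound 1 (`O=C(N/N=C/c1cccc(Cl)c1Cl)Nc1cc2c(Nc3ccc(F)c(Cl)c3)ncnc2cc1O[C@H]1CCOC1`) gives 25000 nM
- compound 2 (`COc1cc(/C=N/NC(=O)Nc2cc3c(Nc4ccc(F)c(Cl)c4)ncnc3cc2O[C@H]2CCOC2)cc(OC)c1OC`) gives 26400 nM
- compound 3 (`O=C(N/N=C/c1ccc(O)c(Br)c1)Nc1cc2c(Nc3ccc(F)c(Cl)c3)ncnc2cc1O[C@H]1CCOC1`) gives 4310 nM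

Compound 1 sits at the high end of these numbers, level with compound 2 within the scatter (a 1.1-fold higher number from compound 1 to compound 2 (0.02 log units; within the scatter)), while compound 3 lies clearly lower (a 5.8-fold lower number from compound 1 to compound 3 (0.76 log units; beyond the scatter)). Compound 4 (`COc1cc2ncnc(Nc3ccc(F)c(Cl)c3)c2cc1NC(=O)N/N=C/c1cccc(Cl)c1Cl`) differs from compound 1 at one place: methyl in place of oxolan-3-yl on an oxygen on an aromatic ring. In words, this is methyl in place of oxolan-3-yl on an oxygen on an aromatic ring. Within the data shown here, no measured step touches that place. All three change the other end of the molecule, and the largest is a 6.1-fold lower number from compound 2 to compound 3 (0.79 log units; beyond the scatter), so they offer only a loose guide to size. No step beyond the scatter is expected, though with low confidence. The expected step is a 1.1-fold lower number from compound 1 to compound 4 (0.06 log units; within the scatter). For compound 4 the estimated value is 22000 nM, with an expected range of 8000 nM to 50000 nM.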

Compound 4, half-maximal inhibitory concentration: 35300 nM
Compound 4: middle estimate off by 1.6-fold (0.21 log units), on the low side, within the range that was stated.
By their numbers in this assay, from the lowest: compound 3; then compounds 1, 2 and 4 (each within the scatter of the next).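

Oxolan-3-yl to methyl on the oxygen on the aromatic ring now has a direct reading in this assay as a 1.4-fold higher number from compound 1 to compound 4 (0.15 log units; within the scatter) and so stays within the scatter with the 2,3-dichlorophenyl end in place. This change also removes the one defined stereocentre and the ring, and the number does not move beyond the scatter. No supporting data bear on this result.

As far as these compounds go, whether the same holds with the 3-bromo-4-hydroxyphenyl end of compound 3 remains open. So does the effect of a longer alkyl chain or an amine-bearing chain on that oxygen.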